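The source may report more compounds than this note shows. Statements on the series, on what has been measured and on what is new or still open speak of the compounds shown alone.

Measured so far: compound 1 `O=C(O)c1ccccc1C1CC(c2cc3ccccc3o2)=NN1C(=O)c1ccncc1` and compound 2 `O=C(c1ccncc1)N1N=C(c2cc3ccccc3o2)CC1c1ccc(O)cc1`.

In an ADME assay on Vero cells (Chlorocebus sabaeus) for cytotoxicity, read by MTT assay, with a stated time of 72 h (on this read-out higher numbers stand for weaker inhibition and lower numbers for stronger inhibition), compound 1 reaches only a limit of the assay, > 170000 nM. In this assay compound 2 likewise reaches only a limit, > 200000 nM. Going by the values given here, compound 2 therefore stands at no fixed number; both values shown for it and its neighbour are limits, as the limit of > 170000 nM in this assay, at which 1 of the 2 values shown sits, and the limit of > 200000 nM in this assay, at which 1 of the 2 values shown sits, state, and the one step between them, a step that the two limits leave unreadable from compound 1 to compound 2, cannot be read.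

Compound 3 `O=C(c1ccncc1)N1N=C(c2cc3ccccc3o2)CC1c1ccccc1Cl` has not yet been measured. It differs from compound 2 in one place: 2-chlorophenyl in place of 4-hydroxyphenyl on a saturated ring carbon. Among the compounds with values here, the only measured step that touches the same saturated ring carbon is a step that the two limits leave unreadable from compound 1 to compound 2, and its size is not readable, so no measured step gives a direction for this exchange. With nothing beyond two limits to build on, compound 3 is expected to sit at the limit again. The step from compound 2 to compound 3 is expected to be a step that the limit leaves unreadable from compound 2 to compound 3, that is, none beyond the scatter. Compound 3 is estimated at 250000 nM, in the range 100000 nM to 700000 nM.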

Compound 3, half-maximal inhibitory concentration: > 210000 nM
Compound 3 was reported as a limit (the forecaster's own chance of this, stated with the estimate: 80%); the middle value does not contradict the limit.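

In this assay compound 3 reaches only a limit of the assay, > 210000 nM. Going by these compounds alone, as compound 1, compound 2 and compound 3 all stand at limits, no step among them can be read. The compounds shown leave open whether any exchange on the saturated ring carbon changes the value in this assay at all.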